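The compounds below may be only part of what the source reports. "The series", "measured", "known", "first", "only" and "open" are said of these compounds alone.

Working notes on the sulfonyl series. Compound 1 `O=C(NCc1ccc(S(=O)(=O)c2ccccc2)cc1)N1Cc2cccnc2C1` and compound 2 `CC(C)n1cc(S(=O)(=O)c2ccc(CNC(=O)N3Cc4ccncc4C3)cc2)cn1` have been measured in a physicochemical assay for solubility, in phosphate buffer, with a stated time of 24 h, at pH 7.4, tested at 100 uM; a lower number here means a less soluble compound, a higher number a more soluble compound. Compound 1 gives 144000 nM, and compound 2 gives 192000 nM; the two numbers sit within the usual scatter of each other, so no order between them is claimed. Compound 3 `O=C(NCc1ccc(S(=O)(=O)N2CCC[C@@H](O)C2)cc1)N1Cc2ccncc2C1` has not yet been measured. It differs from compound 2 in one place: 3-hydroxypiperidin-1-yl in place of 1-isopropyl-1H-pyrazol-4-yl on a sulfonyl sulfur. Going by the values given here, no step between measured compounds bears on this change; the expectation for compound 3 is a small rise beyond the scatter, as a step of a 1.4-fold higher number from compound 2 to compound 3 (0.13 log units; within the scatter). Compound 3 is estimated at 260000 nM, with a range from 150000 nM to 420000 nM.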

Compound 3, solubility: 216000 nM
Beside the measured number, compound 3's estimate is 1.2-fold (0.08 log units) above it; measured number inside the range.
By their numbers in this assay, from the lowest: compounds 1, 2 and 3 (each within the scatter of the next).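

On the sulfonyl sulfur, the swap to 3-hydroxypiperidin-1-yl from 1-isopropyl-1H-pyrazol-4-yl in this assay gives a 1.1-fold higher number from compound 2 to compound 3 (0.05 log units; within the scatter) and so separates the two groups by no more than the scatter. At this place, a six-membered non-aromatic ring with a defined stereocentre therefore reads the same as a five-membered aromatic ring. No measurement shown accounts for this result.

Still open, as far as these compounds go, is whether the opposite stereocentre of the 3-hydroxypiperidin-1-yl group reads the same. Also open, from the compounds shown here alone, is whether a carboxylic acid in place of its hydroxy group would give a step beyond the scatter.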